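The source may hold more compounds than are shown below. What is called first, only, known or untested is meant among the compounds shown, and "the series" means these compounds.

Measured so far:
compound 1, `O=C(/C=C/C1=Cc2ccccc2OC1)c1ccc(F)cc1`: in a functional assay on the whole organism for inhibition, with Mus musculus as the target, with a stated time of 1 h, at a dose of 30 mg/kg by the intraperitoneal route (a lower number here means less inhibition, a higher number more inhibition at the dose given (going by the name of the read-out)), compound 1 gives 65.6%.
compound 2, `O=C(/C=C/C1=Cc2ccccc2OC1)c1ccccc1Br`: in this assay compound 2 gives 56.6%.

Compound 2 carries the lower of the two numbers, yet the step of a number 9 percentage points lower from compound 1 to compound 2 (within the scatter) lies within the scatter, so the two compounds cannot really be told apart on inhibition. Compound 3, `O=C(/C=C/C1=Cc2ccccc2OC1)c1ccc(Br)cc1`, has not yet been measured. It differs from compound 2 in a single way: 4-bromophenyl in place of 2-bromophenyl on a carbonyl carbon. Going by the values given here, only one measured step bears on this change, a number 9 percentage points lower from compound 1 to compound 2 (within the scatter), and it shows that swapping the group on the carbonyl carbon left the read-out within the scatter. Among the compounds with values here, no measured step exchanges one bromophenyl for another. A step of no more than the scatter is therefore expected in this assay, with no clear direction. The estimate for compound 3 is 61%, within 47% to 75%, which means an expected step of a number 4.4 percentage points higher from compound 2 to compound 3 (within the scatter).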

Compound 3, a percentage reported as inhibition, in the whole organism at one dose (the size of the read-out at that dose, not a potency): 66%
The estimate for compound 3 lay 5 percentage points below the measured number; the measured number falls inside the stated range.
By their numbers in this assay, from the lowest: compounds 2, 1 and 3 (each within the scatter of the next).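

With 4-bromophenyl in place of 2-bromophenyl on a carbonyl carbon, this assay shows a number 9.4 percentage points higher from compound 2 to compound 3 (within the scatter), so where the bromine sits on this phenyl ring has no effect that can be told from the scatter at this dose. Bromo in place of fluoro on an aromatic carbon gives a number 0.4 percentage points higher from compound 1 to compound 3 (within the scatter), so these two halogens cannot be told apart here either. No measurement at hand offers an explanation for either step.

From the compounds shown here alone, each group on the carbonyl carbon here is a phenyl ring with a single halogen, so it remains open whether a methoxy group, an amine or a carboxylic acid on that ring would move the read-out beyond the scatter. Going by these compounds, it is also open how an unsubstituted phenyl or a 3-bromophenyl would compare.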